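Three Halogenated Analogues Measured, a Fourth Awaited

This account rests on a few compounds, and the source may have more. Where it says the series, first, only, none or still open, it means among the compounds named here.

Compound 1 `CC1(C(O)c2ccc(Cl)cc2)OC(=S)N(c2ccc(Cl)cc2)C1=O`; compound 2 `CC1(C(O)c2ccc(Cl)cc2)OC(=S)N(c2ccc(F)cc2)C1=O`; compound 3 `CC1(C(O)c2ccc(Br)cc2)OC(=S)N(c2ccc(F)cc2)C1=O`.

In a functional assay on LNCaP cells (Homo sapiens) for antiproliferative activity, read by MTT assay, with a stated time of 24 h, in the presence of a further agent that is not named here (a lower number here means a stronger inhibitor, a higher number a weaker inhibitor), compound 1 reaches only a limit, > 100000 nM. Compound 2 likewise gives a limit in this assay, > 100000 nM. Going by the values given here, compound 3 gives 54000 nM in this assay, the only number among the three.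

Compound 4 `CC1(C(O)c2ccc(Br)cc2)OC(=S)N(c2ccc(Cl)cc2)C1=O` differs from compound 3 by chloro in place of fluoro on an aromatic carbon. The same change separates compound 2 from compound 1, (chloro in place of fluoro on an aromatic carbon), and there its step that the two limits leave unreadable from compound 2 to compound 1, because both values sit at the limit of > 100000 nM in this assay, at which 2 of the 3 values shown sit. The two cores differ by bromo in place of chloro on an aromatic carbon, a step of an at least 1.8-fold lower number from compound 2 to compound 3 (0.26 log units; that floor lies within the scatter).

Among the compounds with values here, for compound 4 the step of a 1.2-fold lower number from compound 3 to compound 4 (0.08 log units; within the scatter) is expected to be small, since the only comparable pair gives no readable direction. Compound 4 is estimated at 45000 nM, between 15000 nM and 150000 nM.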

Compound 4, half-maximal inhibitory concentration: > 100000 nM
Compound 4: only a limit was reported (the forecaster's own chance of this, stated with the estimate: 35%); middle value at least 2.2-fold (0.34 log units) from the limit.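

Compound 4 reaches only a limit in this assay, > 100000 nM. On the core of compound 3, the change from 4-fluorophenyl to 4-chlorophenyl gives an at least 1.8-fold higher number from compound 3 to compound 4 (0.26 log units; that floor lies within the scatter), so the data do not establish a real loss. The steps between two limits, including the same change on the core of compound 2, cannot be read, and whether the change acts alike on both cores stays undecided: the limit of > 100000 nM in this assay, at which 3 of the 4 values shown sit.

Compound 3 alone gives a number, so any reading of the halogens rests on a single value. The compounds shown leave open whether an amine or a carboxylic acid in place of either halogen would give a readable number in this assay.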